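The source may hold more compounds than are shown below. What is called first, only, known or untested is meant among the compounds shown, and "the series" means these compounds.

Three compounds that share one framework were examined in an ADME assay on Vero cells (Chlorocebus sabaeus) for cytotoxicity, read by MTT assay, with a stated time of 72 h; a lower number here means a stronger inhibitor, a higher number a weaker inhibitor. Compound 3 `Cn1cc([N+](=O)[O-])cc1C(=O)NNC(=S)Nc1ccc(F)cc1` gave 662000 nM. Compound 1 `Cn1cc([N+](=O)[O-])cc1C(=O)NNC(=S)Nc1ccc([N+](=O)[O-])cc1` gave 395000 nM. Compound 2 `O=C(NNC(=S)Nc1ccc(F)cc1)c1cc([N+](=O)[O-])c[nH]1` gave 331000 nM. Among these, the step of a 1.7-fold lower number from compound 3 to compound 1 (0.22 log units; within the scatter) arises from nitro in place of fluoro on an aromatic carbon, and the step of a 2.0-fold higher number from compound 2 to compound 3 (0.30 log units; within the scatter) arises from the difference between the two cores, (hydrogen in place of methyl on an aromatic nitrogen). All three values lie within the scatter of one another, so no ordering among them can be claimed.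

Compound 4 `O=C(NNC(=S)Nc1ccc([N+](=O)[O-])cc1)c1cc([N+](=O)[O-])c[nH]1` has not yet been measured in this assay. It differs from compound 2 by nitro in place of fluoro on an aromatic carbon. Within the data shown here, this is the same change as the one from compound 3 to compound 1, made on the other core; the place of the change is described in the same words for both pairs. That earlier change made the step of a 1.7-fold lower number from compound 3 to compound 1 (0.22 log units; within the scatter), which stayed within the scatter.

Among the measured compounds shown here, on this basis, a step of about the same size, a 1.4-fold lower number from compound 2 to compound 4 (0.14 log units; within the scatter), is expected from compound 2 to compound 4 in this assay, because the only precedent, a 1.7-fold lower number from compound 3 to compound 1 (0.22 log units; within the scatter), was small. Compound 4 is accordingly estimated to give 240000 nM in this assay, with the expected range from 120000 nM to 480000 nM, a range that overlaps the values of all three measured compounds.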

Compound 4, half-maximal inhibitory concentration: 529000 nM
For compound 4 the middle estimate is 2.2-fold (0.34 log units) below the measured one; the measured number lies above the stated range.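

In this assay, nitro in place of fluoro on an aromatic carbon gave a 1.6-fold higher number from compound 2 to compound 4 (0.20 log units; within the scatter), and hydrogen in place of methyl on an aromatic nitrogen gave a 1.3-fold higher number from compound 1 to compound 4 (0.13 log units; within the scatter), so neither step alone shows that the change moves the number. Set beside its counterpart on the other core, however, the first change does not carry over as a step of fixed size and direction: the same change on two cores in this assay, a 1.7-fold lower number (0.22 log units; within the scatter) from compound 3 to compound 1 and a 1.6-fold higher number (0.20 log units; within the scatter) from compound 2 to compound 4, 2.7-fold (0.43 log units) apart, beyond the scatter of two such steps The second change does not carry over either, although these four compounds offer only one such comparison for each change and show neither a rule for the wider series nor a reason for the gap: the same change on two cores in this assay, a 2.0-fold higher number (0.30 log units; within the scatter) from compound 2 to compound 3 and a 1.3-fold lower number (0.13 log units; within the scatter) from compound 4 to compound 1, 2.7-fold (0.43 log units) apart, beyond the scatter of two such steps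

The compounds shown leave open whether the same mismatch between the two cores would appear with a chloro group, a methoxy group or an amine in place of fluoro on the six-membered aromatic ring. They also leave open whether an ethyl group or a longer chain in place of methyl on the aromatic nitrogen would give steps that carry from one core to the other.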